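Sulfur-containing ring in place of the saturated hydantoin arm

The source may hold more compounds than are shown below. What is called first, only, known or untested is meant among the compounds shown, and "the series" means these compounds.

Of the compounds shown here, three sharing one core have been measured in a functional assay on CHO cells for antagonist activity at prostaglandin E2 receptor EP3 subtype (Homo sapiens), read by cAMP accumulation, with a stated time of 30 min; on this read-out lower numbers stand for stronger inhibition and higher numbers for weaker inhibition. Compound 1 `CC(C)C(/C=C1\NC(=O)NC1=O)c1ccc(-c2ccc3cccc(F)c3c2)[nH]c1=O` gives 87 nM. Compound 2 `CC(C)C(CC1NC(=O)NC1=O)c1ccc(-c2ccc3cccc(F)c3c2)[nH]c1=O` gives 31 nM, and compound 3 `O=C1NC(=O)/C(=C/C2(c3ccc(-c4ccc5cccc(F)c5c4)[nH]c3=O)CC2)O1` gives 55 nM. Compound 2 has the lowest of the three numbers; its nearest neighbour is compound 3, which sits within the scatter, and the furthest is compound 1, which lies beyond it. For the measured compounds named here, the only step between two compounds that differ in one place is a 2.8-fold lower number from compound 1 to compound 2 (0.45 log units; beyond the scatter), in which the alkylidene-linked ring of compound 1 is replaced by the methylene-linked ring of compound 2.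

Compound 4 `CC(C)C(/C=C1\SC(=O)NC1=O)c1ccc(-c2ccc3cccc(F)c3c2)[nH]c1=O` has not yet been measured. Compared with compound 2 it carries a group of 8 heavy atoms (4 carbon, 1 nitrogen, 2 oxygen, 1 sulfur; one five-membered non-aromatic ring with 2 hetero atoms) in place of a group of 8 heavy atoms (4 carbon, 2 nitrogen, 2 oxygen; one five-membered non-aromatic ring with 2 hetero atoms), on a saturated chain carbon bound to an aromatic carbon and a saturated chain carbon. Going by the values given here, the new arm brings back the exocyclic double bond that compound 1 has, together with a sulfur atom in the five-membered ring, so the one relevant measured step is the one from compound 1 to compound 2, a modest one. Read backwards, it suggests that compound 4 is expected to return to a somewhat higher number than compound 2, roughly a 2.3-fold higher number from compound 2 to compound 4 (0.35 log units; beyond the scatter), with the sulfur swap itself an unknown. Compound 4 is therefore estimated at 70 nM, most likely between 25 nM and 200 nM.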

Compound 4, half-maximal inhibitory concentration: 27 nM
Estimate against measurement, compound 4: 2.6-fold (0.41 log units) above; the measured number falls inside the stated range.
By their numbers in this assay, from the lowest: compounds 4, 2, 3 and 1 (each within the scatter of the next, the first and the last beyond it).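

In this assay, bringing back the double bond together with a sulfur atom in the ring does not return the number to the level of compound 1, and the sulfur-containing arm matches the saturated hydantoin arm, with a 1.1-fold lower number from compound 2 to compound 4 (0.06 log units; within the scatter). Compound 1 and compound 4 both keep the double bond and differ in a single ring atom, nitrogen against sulfur, and that one swap gives a 3.2-fold lower number from compound 1 to compound 4 (0.51 log units; beyond the scatter). The double bond alone therefore does not fix the number at this position: compound 1 carries it with the highest number of the set, while compound 4 carries it with a number level with that of the saturated compound 2.

No measurement available here explains the effect of the sulfur atom. Still open, as far as these compounds go, is how this position would respond to the sulfur-containing ring without its double bond, to an oxygen atom in the sulfur's place on this same chain, or to a carboxylic acid in place of the whole ring.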